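Notes on adding a methoxy group to compound 1

This account rests on a few compounds, and the source may have more. Where it says the series, first, only, none or still open, it means among the compounds named here.

Compound 1 `COc1ccc(C(=O)/C=C/c2ccccc2-c2ccc(F)cc2)cc1OC` gives 7100 nM
Compound 2 `COc1ccc(C(=O)/C=C/c2ccccc2-c2ccc(F)nc2)cc1OC` gives 41000 nM
Compound 3 `COc1ccc(C(=O)/C=C/c2ccccc2-c2ccc(F)cc2)cc1O` gives 560 nM

These values come from a functional assay on MCF7 cells (Homo sapiens) for antiproliferative activity, read by sulforhodamine B assay, with a stated time of 48 h (on this read-out lower numbers stand for stronger inhibition and higher numbers for weaker inhibition), and place compound 1 second highest of the three, with compound 2 higher and compound 3 lower. Compound 4 `COc1cc(C(=O)/C=C/c2ccccc2-c2ccc(F)cc2)cc(OC)c1OC` awaits measurement and carries methoxy in place of hydrogen on an aromatic carbon of compound 1 (methoxy in place of hydrogen on an aromatic carbon).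

Within the data shown here, no measured step makes this same change, and two bear on it only indirectly. The closer one is a 13-fold lower number from compound 1 to compound 3 (1.10 log units; beyond the scatter) with hydrogen in place of methyl on an oxygen on an aromatic ring, a large step on the ring that would gain the new group. The other is a 5.8-fold higher number from compound 1 to compound 2 (0.76 log units; beyond the scatter) with 6-fluoropyridin-3-yl in place of 4-fluorophenyl on an aromatic carbon, a modest step elsewhere in the core. Neither adds a group, so neither fixes a direction. In this assay the expected result is no clear shift beyond the scatter, with a slight lean to a lower number and a wide range. The estimated step is a 1.8-fold lower number from compound 1 to compound 4 (0.25 log units; within the scatter) and remains an expectation. The expected value for compound 4 is 4000 nM (estimated range 800 nM to 20000 nM).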

Compound 4, half-maximal inhibitory concentration: 9100 nM
Estimate against measurement, compound 4: 2.3-fold (0.36 log units) below; the measured number falls inside the stated range.
By their numbers in this assay, from the lowest: compound 3; then compounds 1 and 4 (each within the scatter of the next); then compound 2.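

In this assay, among these compounds, the addition of methoxy in place of hydrogen on an aromatic carbon, ortho to a methoxy group, gives a 1.3-fold higher number from compound 1 to compound 4 (0.11 log units; within the scatter) as the first measured step that adds a group to this ring. This position therefore takes a methoxy group with no shift that can be told from the scatter, while the step on an oxygen of the same ring, a 13-fold lower number from compound 1 to compound 3 (1.10 log units; beyond the scatter) with hydrogen in place of methyl, remains the large change on this ring. No measurement of any property bears on this result.

Open, as far as these compounds go, is whether a different group at this position, such as an amine, a carboxylic acid or a fluorine atom, would leave the number equally unmoved. Also open, from the compounds shown here alone, is whether the same addition would behave alike on compound 2 or compound 3, as methoxy is added here only to compound 1.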